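Estimating Cytotoxicity After a Trifluoroethoxy Swap

The compounds below may be only part of what the source reports. "The series", "measured", "known", "first", "only" and "open" are said of these compounds alone.

Measured in a functional assay on A549 cells (Homo sapiens) for cytotoxicity, read by MTT assay, with a stated time of 72 h; on this read-out lower numbers stand for an effect already at smaller amounts and higher numbers for an effect only at larger amounts of compound:
Compound 1 `CCCOC(=O)c1c(C)coc1-c1ccc2c(CC)cccc2c1OC` gives > 10 ug/mL, a limit of the assay.
Compound 2 `CCc1cccc2c(OC)c(-c3occ(C)c3COC)ccc12` gives > 10 ug/mL, a limit of the assay.
Compound 3 `CCc1cccc2c(OC)c(-c3occ(C)c3CBr)ccc12` gives > 10 ug/mL, a limit of the assay.

Compound 3 thus sits at the limit, as do the two others; in fact (the limit of > 10 ug/mL in this assay, at which 3 of the 3 values shown sit). The change to compound 4 `CCc1cccc2c(OC)c(-c3occ(C)c3COCC(F)(F)F)ccc12` is 2,2,2-trifluoroethoxy in place of bromo on a saturated chain carbon bound to an aromatic carbon. For the measured compounds named here, two measured steps touch the same carbon: a step that the two limits leave unreadable from compound 2 to compound 3 and a step that the two limits leave unreadable from compound 1 to compound 3. Both are unreadable, since every value involved is a limit, so neither a direction nor a size can be drawn from them for this assay. Compound 4 is therefore expected to remain at the limit as well, with an estimated value of 20 ug/mL (range 8 ug/mL to 60 ug/mL), meaning an expected step that the limit leaves unreadable from compound 3 to compound 4.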

Compound 4, concentration for half-maximal effect: > 10 ug/mL
Compound 4: only a limit was reported (the forecaster's own chance of this, stated with the estimate: 85%); the middle value does not contradict the limit.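

No step can be read among compound 1, compound 2, compound 3 and compound 4, since each result is only a limit: the limit of > 10 ug/mL in this assay, at which 4 of the 4 values shown sit. From the compounds shown here alone, how these four compounds would rank at larger amounts remains open.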